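The source may report more compounds than this note shows. Statements on the series, on what has been measured and on what is new or still open speak of the compounds shown alone.

Measured so far:
compound 1 `C#CCOC(=O)/C(C)=C/CC/C(C)=C/CC/C(C)=C/CC[C@@H]1[C@@]2(C)CCC(=O)C(C)(C)[C@H]2CC[C@@]1(C)O` — 27400 nM
compound 2 `C/C(=C\CC/C(C)=C/CC[C@@H]1[C@@]2(C)CCC(=O)C(C)(C)[C@H]2CC[C@@]1(C)O)CC/C=C(\C)C(=O)OCc1cn([C@@H]2C[C@@H](n3cc(C)c(=O)[nH]c3=O)O[C@H]2CO)nn1` — 55600 nM

Both were run in a functional assay on HT-29 cells (Homo sapiens) for antiproliferative activity, read by MTT assay, with a stated time of 48 h; a lower number here means a stronger inhibitor, a higher number a weaker inhibitor. Compound 1 gives the lower of the two numbers, at 27400 nM. Compound 2 gives 55600 nM, a higher number, and the gap between the two is beyond the scatter. Within the data shown here, no pair differing in one place has been measured, so nothing in the set yet shows how a change at the oxygen next to the carbonyl group moves this assay.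

Compound 3 `C/C(=C\CC/C(C)=C/CC[C@@H]1[C@@]2(C)CCC(=O)C(C)(C)[C@H]2CC[C@@]1(C)O)CC/C=C(\C)C(=O)O` is not yet measured. It differs from compound 1 as follows: hydrogen in place of propargyl on an oxygen next to a carbonyl group, that is propargyloxycarbonyl to carboxy. Among the measured compounds shown here, with only two weak numbers in hand, the expected step is small, no more than modestly toward a higher number, a 1.3-fold higher number from compound 1 to compound 3 (0.11 log units; within the scatter). Compound 3 is estimated at 35000 nM, with a range of 12000 nM to 100000 nM.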

Compound 3, half-maximal inhibitory concentration: 56600 nM
For compound 3 the middle estimate is 1.6-fold (0.21 log units) below the measured one; the measured number falls inside the stated range.
By their numbers in this assay, from the lowest: compound 1; then compounds 2 and 3 (each within the scatter of the next).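

In this assay, among these compounds, hydrogen in place of propargyl on an oxygen next to a carbonyl group gives the first one-place reading for this position: a 2.1-fold higher number from compound 1 to compound 3 (0.32 log units; beyond the scatter), a modest step just beyond the scatter. Propargyloxycarbonyl to carboxy therefore moves the number in the direction of weaker inhibition, and the free carboxy compound offers no gain over the propargyl ester. Nothing available explains the size or direction of this step.

The compounds shown leave open whether the step depends on the triple bond of propargyl or simply on having a carbon chain on this oxygen, a question a propyl ester at the same place would address. Also open, from the compounds shown here alone, is whether a methyl ester or a primary amide would sit nearer compound 1 or compound 3.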